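The compounds below may be only part of what the source reports. "The series", "measured", "known", "first", "only" and "open" are said of these compounds alone.

Compound 1 `O=C(Nc1cccc(-n2cc(-c3ccncc3)c(-c3ccc(Cl)c(O)c3)n2)c1)Nc1cccc(C(F)(F)F)c1` gives 2120 nM in a functional assay on TK-10 cells (Homo sapiens) for inhibition, read by sulforhodamine B assay, with a stated time of 48 h (on this read-out lower numbers stand for stronger inhibition of growth and higher numbers for weaker inhibition of growth), and so stands as the highest of the two numbers in hand. Compound 2 `O=C(Nc1cccc(-n2cc(-c3ccncc3)c(-c3ccc(Cl)c(O)c3)n2)c1)Nc1cc(C(F)(F)F)cc(C(F)(F)F)c1` gives 959 nM in this assay. Within the data shown here, the single measured step, trifluoromethyl in place of hydrogen, gave a 2.2-fold lower number from compound 1 to compound 2 (0.34 log units; beyond the scatter). Compound 3 `O=C(Nc1cccc(-n2cc(-c3ccncc3)c(-c3ccc(Cl)c(O)c3)n2)c1)Nc1ccc(Cl)c(C(F)(F)F)c1` differs from compound 1 by chloro in place of hydrogen on an aromatic carbon, the chloro entering ortho to a trifluoromethyl group. Among the measured compounds shown here, only the step from compound 1 to compound 2 bears on this, and it was modest. A step of similar direction and size is therefore expected, a 1.8-fold lower number from compound 1 to compound 3 (0.25 log units; within the scatter). For compound 3 the estimate is 1200 nM, with a range from 500 nM to 2800 nM.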

Compound 3, concentration for 50% growth inhibition: 1500 nM
The estimate for compound 3 lay 1.3-fold (0.10 log units) below the measured number; low and high end bracket the measured number.
By their numbers in this assay, from the lowest: compounds 2, 3 and 1 (each within the scatter of the next, the first and the last beyond it).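

Chloro in place of hydrogen, ortho to a trifluoromethyl group and para to a large group, gave a 1.4-fold lower number from compound 1 to compound 3 (0.15 log units; within the scatter) in this assay and so brought no readable change at this position. Among these compounds, the earlier trifluoromethyl step, a 2.2-fold lower number from compound 1 to compound 2 (0.34 log units; beyond the scatter) and at a different position, is the only change in the set that clears the scatter. Nothing measured here speaks to the cause of either step.

From the compounds shown here alone, whether an amine, a methoxy group or a carboxylic acid at this position would also leave the number unchanged remains open. So does the effect of chloro at this position on the aryl group of compound 2.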